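Moving a fluorine from the 2- to the 3-position

The source may hold more compounds than are shown below. What is called first, only, known or untested is meant among the compounds shown, and "the series" means these compounds.

Compound 1, `Oc1cccc(-c2cc(-c3ccccc3F)cc(-c3ccccc3O)n2)c1`, in a functional assay on HeLa cells (Homo sapiens) for inhibition; on this read-out lower numbers stand for stronger inhibition and higher numbers for weaker inhibition: 31100 nM
Compound 2, `Oc1cccc(-c2cc(-c3cccc(F)c3)cc(-c3ccccc3O)n2)c1`, in this assay: > 50000 nM, which is a limit of the assay, not a number
Compound 3, `Oc1cccc(-c2cc(-c3ccccc3F)cc(-c3cccc(O)c3)n2)c1`, in this assay: 16000 nM

Compound 3 gives the lowest of the two numbers shown, but the gap a 1.9-fold lower number from compound 1 to compound 3 (0.29 log units; within the scatter) is within the scatter, so compound 3 and compound 1 cannot be ranked. Among the measured compounds shown here, the only third value is the limit (the limit of > 50000 nM in this assay, at which 1 of the 3 values shown sits).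

Compound 4, `Oc1cccc(-c2cc(-c3cccc(F)c3)cc(-c3cccc(O)c3)n2)c1`, is not yet measured. It differs from compound 3 in one place: 3-fluorophenyl in place of 2-fluorophenyl on an aromatic carbon.

The same change at the same place has been measured once, in the step of an at least 1.6-fold higher number from compound 1 to compound 2 (0.20 log units; that floor lies within the scatter). From the compounds shown here alone, its floor lies within the scatter, and the end point is a limit, so the true size is unknown; it may be small or large, but the direction was toward a higher number. On that single step, compound 4 is expected to give a higher number than compound 3, with the step of a 2.2-fold higher number from compound 3 to compound 4 (0.34 log units; beyond the scatter). The estimate for compound 4 in this assay is therefore 35000 nM, with a range from 15000 nM to 90000 nM, and a real chance that only a limit is returned.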

Compound 4, half-maximal inhibitory concentration: 1400 nM
Compound 4: the middle estimate sits 25-fold (1.40 log units) above what was measured; the whole stated range lies above it.
By their numbers in this assay, from the lowest: compound 4; then compounds 3 and 1 (each within the scatter of the next). At a limit, above all of these: compound 2.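

In this assay, replacing 2-fluorophenyl with 3-fluorophenyl opposite the ring nitrogen has no fixed effect: with two 3-hydroxyphenyl groups on the core it gives an 11-fold lower number from compound 3 to compound 4 (1.06 log units; beyond the scatter), so the earlier step does not carry over to this core: the same change on two cores in this assay, an at least 1.6-fold higher number (0.20 log units; that floor lies within the scatter) from compound 1 to compound 2 and an 11-fold lower number (1.06 log units; beyond the scatter) from compound 3 to compound 4, at least 18-fold (1.26 log units) apart, beyond the scatter of two such steps. The hydroxyl change depends on its partner in the same way, and with 3-fluorophenyl on the core it gives an at least 35-fold lower number from compound 2 to compound 4 (1.55 log units; beyond the scatter), so the two places do not act independently: the same change on two cores in this assay, a 1.9-fold lower number (0.29 log units; within the scatter) from compound 1 to compound 3 and an at least 35-fold lower number (1.55 log units; beyond the scatter) from compound 2 to compound 4, at least 18-fold (1.26 log units) apart, beyond the scatter of two such steps. The value of compound 2, > 50000 nM, is a limit of the assay, and this step is therefore a floor rather than a full size.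

The compounds shown leave open what lies behind this dependence between the two places, and whether it is specific to fluorine or would also appear with a chlorine, an amine or a carboxylic acid in its place. They also cannot tell whether the effect needs both hydroxyl groups, as a methyl ether at either one would test.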